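From nitro to bromo in a small compound series

This account rests on a few compounds, and the source may have more. Where it says the series, first, only, none or still open, it means among the compounds named here.

- compound 1 `Cc1noc(NS(=O)(=O)c2ccc(NC(=O)c3cc4ccccc4oc3=O)cc2)c1C` gives 19900 nM
- compound 2 `Cc1noc(NS(=O)(=O)c2ccc(NC(=O)c3cc4cc([N+](=O)[O-])ccc4oc3=O)cc2)c1C` gives 11900 nM
- compound 3 `CCOc1ccc(NC(=O)c2cc3cc([N+](=O)[O-])ccc3oc2=O)cc1` gives 12100 nM

Compound 2 at 11900 nM sits within the usual scatter of both compound 3 and compound 1 in a functional assay on PANC-1 cells (Homo sapiens) for antiproliferative activity, read by fluorescence and resazurin assay, with a stated time of 48 h (on this read-out higher numbers stand for weaker inhibition and lower numbers for stronger inhibition), so these numbers do not rank it against either neighbour.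

The next compound to be tested is compound 4 `Cc1noc(NS(=O)(=O)c2ccc(NC(=O)c3cc4cc(Br)ccc4oc3=O)cc2)c1C`, which differs from compound 2 in one place (bromo in place of nitro on an aromatic carbon). For the measured compounds named here, no measured compound carries bromo, so the data say nothing direct about this group.

Two measured steps still give a sense of scale. Nitro in place of hydrogen on an aromatic carbon gave a 1.7-fold lower number from compound 1 to compound 2 (0.22 log units; within the scatter) in this assay on the way to the nitro compound. Ethoxy in place of (3,4-dimethyl-1,2-oxazol-5-yl)sulfamoyl gave a 1.0-fold higher number from compound 2 to compound 3 (0.01 log units; within the scatter) in the same test. Neither change moved the number beyond the scatter, even though the second replaced a large group. On that evidence, swapping nitro for bromo is not expected to produce a real shift in either direction.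

An estimated 1.1-fold higher number from compound 2 to compound 4 (0.04 log units; within the scatter) is therefore expected, which is no step beyond the scatter.

The expected value for compound 4 is 13000 nM within an estimated range of 6000 nM to 28000 nM in this series.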

Compound 4, half-maximal inhibitory concentration: 28700 nM
Compound 4: middle estimate off by 2.2-fold (0.34 log units), on the low side, outside the stated range (above it).
By their numbers in this assay, from the lowest: compounds 2, 3, 1 and 4 (each within the scatter of the next, the first and the last beyond it).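

For the compounds shown here, at this position, bromo in place of nitro is the first single change to move the number beyond the scatter: in this assay it gives a 2.4-fold higher number from compound 2 to compound 4 (0.38 log units; beyond the scatter), so the two groups can be told apart on this aromatic carbon even though neither stands out from hydrogen. Bromo in place of hydrogen gives a 1.4-fold higher number from compound 1 to compound 4 (0.16 log units; within the scatter), which is within the scatter, as is the earlier step of a 1.7-fold lower number from compound 1 to compound 2 (0.22 log units; within the scatter), so compound 1 cannot be ranked against either compound 2 or compound 4, and only the two substituted compounds are separated from each other. Nothing measured here explains the gap between nitro and bromo.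

The compounds shown leave open whether an amine or a carboxylic acid on this aromatic carbon would give a number clearly lower than that of compound 2, which would show whether this position can do more than separate two groups. Going by these compounds alone, the gap is also seen only with the (3,4-dimethyl-1,2-oxazol-5-yl)sulfamoyl group in place, so whether it holds alongside the ethoxy group of compound 3 remains an open question.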